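Trimming a Nitrooxy Chain by One Carbon

The compounds below may be only part of what the source reports. "The series", "measured", "known", "first", "only" and "open" are said of these compounds alone.

In a functional assay on SKBR cells (Homo sapiens) for cytotoxicity, read by resazurin assay, with a stated time of 72 h (a lower number here means a stronger inhibitor, a higher number a weaker inhibitor), compound 1 (`COc1cc(/C=C/C(=O)OCCCCOc2no[n+]([O-])c2S(=O)(=O)c2ccccc2)ccc1O`) gives 420 nM as its value. Compound 2 (`COc1cc(/C=C/C(=O)OCCCCCCO[N+](=O)[O-])ccc1O`) gives 15200 nM and stands higher of the two, beyond the scatter, which makes it the weaker inhibitor. Compound 3 (`COc1cc(/C=C/C(=O)OCCCCCO[N+](=O)[O-])ccc1O`) differs from compound 2 by one change (nitrooxy in place of (nitrooxy)methyl on a saturated chain carbon, five bonds along the chain from an oxygen next to a carbonyl group), with nitrooxy in place of (nitrooxy)methyl on a saturated chain carbon, five bonds along the chain from an oxygen next to a carbonyl group. Among the compounds with values here, no measured step shows this change, but in this assay the estimated step of a 1.2-fold higher number from compound 2 to compound 3 (0.07 log units; within the scatter) is expected to stay within the scatter. Compound 3 is estimated at 18000 nM (range 7000 nM to 45000 nM).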

Compound 3, half-maximal inhibitory concentration: 8060 nM
Estimate against measurement, compound 3: 2.2-fold (0.35 log units) above; the range from low to high includes it.
By their numbers in this assay, from the lowest: compound 1; then compounds 3 and 2 (each within the scatter of the next).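

Swapping (nitrooxy)methyl for nitrooxy on this saturated chain carbon gives a 1.9-fold lower number from compound 2 to compound 3 (0.28 log units; within the scatter) in this assay. Within the data shown here, this is the first direct look at this change, and it shows that removing this one chain carbon leaves the reading within the usual scatter, something compound 1 and compound 2 alone could not show. Nothing measured here offers an explanation for this result. Still open, as far as these compounds go, is whether a much shorter or longer chain would move the number beyond the scatter, and how an amine or a carboxylic acid in place of nitrooxy would read.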